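Aryl imine variation on the shared core: compound 4

The source may hold more compounds than are shown below. What is called first, only, known or untested is meant among the compounds shown, and "the series" means these compounds.

Measured compounds in a functional assay on MCF7 cells (Homo sapiens) for antiproliferative activity, read by CCK-8 assay; a lower number here means a stronger inhibitor, a higher number a weaker inhibitor:
compound 1 `Clc1ccc(/C=N/c2nnc(SCc3c[se]c(-c4ccccc4)n3)s2)cc1` gives 4020 nM
compound 2 `Brc1ccc(/C=N/c2nnc(SCc3c[se]c(-c4ccccc4)n3)s2)cc1` gives 14800 nM
compound 3 `COc1cc(/C=N/c2nnc(SCc3c[se]c(-c4ccccc4)n3)s2)ccc1O` gives 15000 nM

Compound 3 carries the highest number of the three. Against compound 2 the gap is a 1.0-fold higher number from compound 2 to compound 3 (0.01 log units; within the scatter), so the two cannot be told apart; against compound 1 it is a 3.7-fold higher number from compound 1 to compound 3 (0.57 log units; beyond the scatter), a modest but real difference. The remaining step, a 3.7-fold higher number from compound 1 to compound 2 (0.57 log units; beyond the scatter), is of the same modest size.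

Compound 4 `CN(C)c1ccc(/C=N/c2nnc(SCc3c[se]c(-c4ccccc4)n3)s2)cc1` differs from compound 3 in one place: 4-(dimethylamino)phenyl in place of 4-hydroxy-3-methoxyphenyl on a carbon with a double bond to nitrogen. Among the measured compounds shown here, no measured pair covers this exchange. What the three compounds show is that swapping the aryl group on the carbon double-bonded to nitrogen moves the number in this assay little or modestly: a 3.7-fold higher number from compound 1 to compound 3 (0.57 log units; beyond the scatter) and a 3.7-fold higher number from compound 1 to compound 2 (0.57 log units; beyond the scatter) were modest, a 1.0-fold higher number from compound 2 to compound 3 (0.01 log units; within the scatter) lay within the scatter. The step to compound 4 is therefore expected to be modest at most, with the direction not fixed by the data, and the range is set wide for that reason. Compound 4 is estimated at 9000 nM, within a range from 2500 nM to 35000 nM. This corresponds to an expected step of a 1.7-fold lower number from compound 3 to compound 4 (0.22 log units; within the scatter).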

Compound 4, half-maximal inhibitory concentration: 80300 nM
Estimate against measurement, compound 4: 8.9-fold (0.95 log units) below; measured number above the stated range.
By their numbers in this assay, from the lowest: compound 1; then compounds 2 and 3 (each within the scatter of the next); then compound 4.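

In this assay, among the compounds shown here, the aryl group on the carbon with a double bond to nitrogen can shift the number by more than the first three compounds indicated: dimethylamino in place of chloro on the aromatic carbon gives the one large step (a 20-fold higher number from compound 1 to compound 4 (1.30 log units; beyond the scatter)). Compound 4 also stands apart from the two compounds that could not be separated from each other, with 4-(dimethylamino)phenyl in place of 4-hydroxy-3-methoxyphenyl (a 5.4-fold higher number from compound 3 to compound 4 (0.73 log units; beyond the scatter)) and dimethylamino in place of bromo (a 5.4-fold higher number from compound 2 to compound 4 (0.73 log units; beyond the scatter)) each giving a modest step in the same direction. The groups exchanged between compound 3 and compound 4 have the same count of heavy atoms, so that count does not separate them, and nothing measured here explains the higher number of compound 4.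

Still open, going by these compounds, is whether the dimethylamino group as a whole sets this result, which 4-aminophenyl or 4-(diethylamino)phenyl on the same carbon would test. Also open, on these data alone, is whether any aryl group at this place can go below compound 1, with 4-fluorophenyl and 4-carboxyphenyl as plain next comparisons against the chloro and bromo pair.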